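Dimethylphenyl variation in a diacylhydrazine ecdysone agonist series

The compounds below may be only part of what the source reports. "The series", "measured", "known", "first", "only" and "open" are said of these compounds alone.

Measured compounds in an assay on cells for agonist activity at ecdysone receptor (Bombyx mori), read by a luciferase reporter, with a stated time of 24 h; a lower number here means that less compound is needed, a higher number that more compound is needed for the effect:
compound 1 `CC(C)(C)N(NC(=O)c1ccccc1)C(=O)c1ccccc1Cl` gives 75.9 nM
compound 2 `CC(C)(C)N(NC(=O)c1ccc(C#N)cc1)C(=O)c1ccccc1Cl` gives 603 nM
compound 3 `Cc1cccc(C(=O)NN(C(=O)c2ccccc2Cl)C(C)(C)C)c1C` gives 20 nM

Compound 3 holds the lowest number of the three. Its nearest neighbour is compound 1, which is a 3.8-fold lower number from compound 1 to compound 3 (0.58 log units; beyond the scatter), and its furthest is compound 2, a 30-fold lower number from compound 2 to compound 3 (1.48 log units; beyond the scatter). Compound 2 itself falls away from compound 1, a 7.9-fold higher number from compound 1 to compound 2 (0.90 log units; beyond the scatter).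

Compound 4 `Cc1ccc(C)c(C(=O)NN(C(=O)c2ccccc2Cl)C(C)(C)C)c1` keeps the shared core of compound 3 and moves one methyl: 2,5-dimethylphenyl in place of 2,3-dimethylphenyl on a carbonyl carbon. Within the data shown here, no measured pair speaks to this rearrangement directly. Among the measured compounds shown here, the steps that bear on it are the two that change the same aryl group: the gain on going to the 2,3-dimethylphenyl of compound 3 and the loss on going to the cyano-bearing ring of compound 2. Both show the assay responding to this ring, but neither says whether the second methyl is tolerated equally at the other position. The two compounds share all atoms, so compound 4 is expected to land near compound 3, with the step of a 1.8-fold higher number from compound 3 to compound 4 (0.24 log units; within the scatter) most likely within or only slightly beyond the scatter, and if anything upward. Compound 4 is therefore estimated at 35 nM, in the range 10 nM to 120 nM.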

Compound 4, half-maximal effective concentration: 1620 nM
Beside the measured number, compound 4's estimate is 46-fold (1.67 log units) below it, and the stated range ends below it.
By their numbers in this assay, from the lowest: compound 3; then compound 1; then compound 2; then compound 4.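

In this assay, the arrangement of the two methyls on this ring decides the outcome even with the atoms unchanged (an 81-fold higher number from compound 3 to compound 4 (1.91 log units; beyond the scatter)), so the 2,3-dimethylphenyl and 2,5-dimethylphenyl groups are not interchangeable on this carbonyl carbon. Adding two methyls to the phenyl group does not in itself lower the number: the 2,3-dimethylphenyl group of compound 3 gave a lower number than the phenyl group of compound 1, whereas the 2,5-dimethylphenyl group goes the other way (a 21-fold higher number from compound 1 to compound 4 (1.33 log units; beyond the scatter)). The 2,5-dimethylphenyl group also ends up above the 4-cyanophenyl group (a 2.7-fold higher number from compound 2 to compound 4 (0.43 log units; beyond the scatter)), which makes compound 4 the least potent of the four in this assay and shows that a change of methyl placement alone can cost more here than the nitrile did.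

No supporting data bear on why the two methyl arrangements part so sharply. From the compounds shown here alone, it remains open how a phenyl carrying a single methyl would read in this assay, and whether a methoxy or an amine in place of either methyl would follow the same dependence on arrangement.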